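The Same Swap Tried on a Second Core

The source may report more compounds than this note shows. Statements on the series, on what has been measured and on what is new or still open speak of the compounds shown alone.

compound 1 `Cc1nnc(SCc2cc(=O)c3cc(Cl)ccc3o2)o1` — > 25000 nM
compound 2 `Nc1nnc(SCc2cc(=O)c3cc(Cl)ccc3o2)s1` — > 25000 nM
compound 3 `Cc1nnc(SCc2coc3ccccc3c2=O)o1` — 3800 nM

In a functional assay on HEp-2 cells (Homo sapiens) for cytotoxicity, read by MTT assay, with a stated time of 72 h (a lower number here means a stronger inhibitor, a higher number a weaker inhibitor), compound 1 gives > 25000 nM, a limit of the assay rather than a number. Compound 2 likewise gives > 25000 nM, also a limit. The change between them, (5-amino-1,3,4-thiadiazol-2-yl in place of 5-methyl-1,3,4-oxadiazol-2-yl on a sulfur), thus yields a step that the two limits leave unreadable from compound 1 to compound 2, and the limit of > 25000 nM in this assay, at which 2 of the 3 values shown sit, is all that this pair shows. Among the compounds with values here, compound 3 gives 3800 nM in this assay, the only number among the three; the difference between its core and that of compound 1 is not broken down here. Compound 4 `Nc1nnc(SCc2coc3ccccc3c2=O)s1` carries the same change, (5-amino-1,3,4-thiadiazol-2-yl in place of 5-methyl-1,3,4-oxadiazol-2-yl on a sulfur), at the same place. From the compounds shown here alone, because a step that the two limits leave unreadable from compound 1 to compound 2 stands between compound 1 and compound 2, the size of this step is unknown, so the expectation for compound 4 rests on compound 3 alone and is wide. Compound 4 is expected to move by a 1.6-fold higher number from compound 3 to compound 4 (0.20 log units; within the scatter), to an estimated 6000 nM within 1500 nM to 25000 nM.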

Compound 4, half-maximal inhibitory concentration: 1500 nM
Estimate against measurement, compound 4: 4.0-fold (0.60 log units) above, within the range that was stated.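

In this assay, 5-amino-1,3,4-thiadiazol-2-yl in place of 5-methyl-1,3,4-oxadiazol-2-yl on a sulfur gives a 2.5-fold lower number from compound 3 to compound 4 (0.40 log units; beyond the scatter), a modest step on this core. On the core of compound 1, the same change cannot be read, because compound 1 and compound 2 both give a limit of the assay rather than a number: the limit of > 25000 nM in this assay, at which 2 of the 4 values shown sit. The change is therefore sized on one core only, and whether the step carries over to the other core is not shown.

The compounds shown leave open which part of the change goes with the step. The 5-amino-1,3,4-oxadiazol-2-yl and 5-methyl-1,3,4-thiadiazol-2-yl groups, each changing only the amine or only the ring, would separate the two.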